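This account rests on a few compounds, and the source may have more. Where it says the series, first, only, none or still open, it means among the compounds named here.

Working notes on the series. Of the compounds shown here, three have been measured in an assay on isolated protein for inhibition of prostaglandin G/H synthase 1 (Mus musculus), tested at 10 ug/mL; a higher number here means more inhibition at the concentration tested (going by the name of the read-out), a lower number less inhibition: compound 1 `CS(=O)(=O)c1ccc(-c2oc3ccccc3c(=S)c2-c2ccc(F)cc2)cc1`, compound 2 `CS(=O)(=O)c1ccc(-c2oc3ccccc3c(=O)c2-c2ccc(F)cc2)cc1` and compound 3 `COc1ccc(-c2c(-c3ccc(S(C)(=O)=O)cc3)oc3ccccc3c2=S)cc1`. Every reported value is a limit of the assay rather than a number. For compound 1 this assay gives < 5%, a limit. For compound 2 it gives < 8%, also a limit. For compound 3 it gives < 5%, again a limit. Among the compounds with values here, the one step in which two measured compounds differ in a single place is a step that the two limits leave unreadable from compound 1 to compound 3; with both ends at a limit its size cannot be read. Compound 2 therefore stands at a limit, with the two other values in the series also sitting at limits the limit of < 5% in this assay, at which 2 of the 3 values shown sit (the limit of < 8% in this assay, at which 1 of the 3 values shown sits).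

The next compound is compound 4 `CS(=O)(=O)c1ccc(-c2oc3ccccc3c(=O)c2-c2ccccc2)cc1`. It differs from compound 2 by hydrogen in place of fluoro on an aromatic carbon. Within the data shown here, the only measured step, from compound 1 to compound 3, changes the same ring but is unreadable, so no measured step gives a size for this change. The expectation for compound 4 in this assay is a step that the limit leaves unreadable from compound 2 to compound 4 from compound 2, which means no change beyond the scatter. Compound 4 is estimated at 4%, within 0% to 12%, most likely reported again as a limit.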

Compound 4, a percentage reported as inhibition, at one concentration (the size of the read-out at that concentration, not a potency): < 5%
Compound 4 ended at the assay's limit; the forecaster's own chance of this, stated with the estimate: 85%; the middle value is on the limit's open side.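

Compound 2 and compound 4 both stand at a limit of the assay, so the step from 4-fluorophenyl to phenyl cannot be read. The compounds shown leave open whether any change on the shared core gives a readable level of inhibition in this assay.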